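From thiophen-2-yl to 5-chlorothiophen-2-yl: one added chloro

This account rests on a few compounds, and the source may have more. Where it says the series, first, only, none or still open, it means among the compounds named here.

Values measured in an ADME assay on MDCK cells (Canis lupus familiaris) for cytotoxicity, read by MTT assay, with a stated time of 24 h; on this read-out lower numbers stand for higher toxicity in this test and higher numbers for lower toxicity in this test
Compound 1 `Cc1cc(CNS(=O)(=O)c2ccc([N+](=O)[O-])cc2)c(C)o1` gives > 152000 nM
Compound 2 `O=[N+]([O-])c1ccc(S(=O)(=O)NCc2ccsc2)cc1` gives 139000 nM
Compound 3 `O=[N+]([O-])c1ccc(S(=O)(=O)NCc2cccs2)cc1` gives 133000 nM

The entry for compound 1 is a limit of the assay and not a number. Compound 3 sits level with compound 2 in this assay and the gap between them (a 1.0-fold lower number from compound 2 to compound 3 (0.02 log units; within the scatter)) stays within the scatter. Compound 4 `O=[N+]([O-])c1ccc(S(=O)(=O)NCc2ccc(Cl)s2)cc1` differs from compound 3 by one change (chloro in place of hydrogen on an aromatic carbon) with chloro in place of hydrogen on an aromatic carbon. Within the data shown here, no measured step adds chloro. The closest steps swap the whole ring group, and both an at least 1.0-fold lower number from compound 1 to compound 2 (0.03 log units; that floor lies within the scatter) and an at least 1.1-fold lower number from compound 1 to compound 3 (0.05 log units; that floor lies within the scatter) have floors within the scatter. A step within the scatter is therefore expected, leaning towards a lower number. The expected change is a 1.3-fold lower number from compound 3 to compound 4 (0.10 log units; within the scatter) in this estimate. Compound 4 is estimated at 105000 nM (range 50000 nM to 170000 nM).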

Compound 4, half-maximal cytotoxic concentration: 128000 nM
Beside the measured number, compound 4's estimate is 1.2-fold (0.09 log units) below it, within the range that was stated.
By their numbers in this assay, from the lowest: compounds 4, 3 and 2 (each within the scatter of the next). At a limit, above all of these: compound 1.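

In this assay, chloro in place of hydrogen next to the ring sulfur gives a 1.0-fold lower number from compound 3 to compound 4 (0.02 log units; within the scatter) and so no readable change at this position. The 5-chlorothiophen-2-yl group also sits level with thiophen-3-yl, the step being a 1.1-fold lower number from compound 2 to compound 4 (0.04 log units; within the scatter) here. The remaining step, an at least 1.1-fold lower number from compound 1 to compound 4 (0.07 log units; that floor lies within the scatter), has only a floor, and its starting point is a limit and not a number: the limit of > 152000 nM in this assay, at which 1 of the 4 values shown sits.

On these data alone, whether an amine or a carboxylic acid at this position would move the number beyond the scatter stays open. So does the effect of chloro on thiophen-3-yl.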